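The source may report more compounds than this note shows. Statements on the series, on what has been measured and on what is new or still open speak of the compounds shown alone.

Measured so far:

compound 1, `C[C@H](NC(=O)Nc1ccccc1C(C)(C)C)c1ccccc1`: 99%
compound 2, `C[C@H](NC(=O)Nc1ccccc1F)c1ccccc1`: 92%
compound 3, `C[C@H](NC(=O)Nc1ccccc1Br)c1ccccc1`: 99%

All three compounds share one core and differ only in the group on one aromatic carbon. In an ADME assay on the whole organism with Oryza sativa as the target, tested at 1 uM (on this read-out lower numbers stand for a stronger effect and higher numbers for a weaker effect at the one concentration tested), compound 1 gives 99% and stands level with compound 3, the two together being the highest of the three numbers. Its nearest neighbour is compound 3, with no change at the digits printed from compound 1 to compound 3 (within the scatter); its furthest is compound 2, with a number 7 percentage points lower from compound 1 to compound 2 (within the scatter). The remaining pair shows a number 7 percentage points higher from compound 2 to compound 3 (within the scatter). Every measured step thus stays within the scatter.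

Compound 4, `C[C@H](NC(=O)Nc1cc(C(C)(C)C)ccc1C(C)(C)C)c1ccccc1`, keeps everything in compound 1 and adds one group: tert-butyl in place of hydrogen on an aromatic carbon. The new group sits on an aromatic carbon of a six-membered aromatic ring of carbon only, meta to a large group and para to a tert-butyl group. Among the compounds with values here, no measured step adds a group at an open position; the three known steps only swap one group for another at a single place, and none of them moved the number beyond the scatter. The nearest guide is therefore the flat picture across compounds 1, 2 and 3, and the step from compound 1 to compound 4 is expected to be a number 2 percentage points lower from compound 1 to compound 4 (within the scatter), that is, no change beyond the scatter. On that basis compound 4 is estimated at 97%, with a range from 86% to 100%.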

Compound 4, a percentage reported as activity, at one concentration (the size of the read-out at that concentration, not a potency): 98%
Compound 4: middle estimate off by 1 percentage points, on the low side, within the range that was stated.
By their numbers in this assay, from the lowest: compounds 2, 4, 1 and 3 (each within the scatter of the next).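

In this assay the addition of tert-butyl in place of hydrogen, on an aromatic carbon meta to a large group and para to a tert-butyl group, gives a number 1 percentage points lower from compound 1 to compound 4 (within the scatter) and so leaves the read-out flat. Within the data shown here, the earlier steps only swapped one group for another at a single place, so this is the first sign that filling an open position on this ring can also stay within the scatter. Nothing among the data shown explains this flat result.

Still open, on these data alone, is whether a different group at this same position, such as an amine or a carboxylic acid, would move the number beyond the scatter. Also open, as far as these compounds go, is whether adding the same tert-butyl to compound 2 or compound 3 would leave their numbers just as flat.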